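This account rests on a few compounds, and the source may have more. Where it says the series, first, only, none or still open, it means among the compounds named here.

Working notes on the series.

Compound 1 `COc1ccc(-n2c(SCC(=O)C3CC3)nnc2-c2cc(OC)c(OC)c(OC)c2)cc1` is the reference point. In a functional assay on PC-3 cells (Homo sapiens) for inhibition, read by MTT assay, with a stated time of 48 h (a lower number here means a stronger inhibitor, a higher number a weaker inhibitor), compound 1 gives 37200 nM. Compound 2 `CCOC(=O)CSc1nnc(-c2cc(OC)c(OC)c(OC)c2)n1-c1ccc(OC)cc1` differs from compound 1 by ethoxy in place of cyclopropyl on a carbonyl carbon. For compound 2 the result in this assay is only a limit, > 60000 nM, and not a number. The step reads an at least 1.6-fold higher number from compound 1 to compound 2 (0.20 log units; that floor lies within the scatter); it rests on (the limit of > 60000 nM in this assay, at which 1 of the 3 values shown sits), so its true size is not fixed.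

Compound 3 `COc1cc(-c2nnc(SCC(=O)C3CC3)n2-c2ccc(N(C)C)cc2)cc(OC)c1OC` carries the same side chain as compound 1, and its core differs from that of compound 1 by dimethylamino in place of methoxy on an aromatic carbon. In this assay compound 3 gives 45900 nM. The step of a 1.2-fold higher number from compound 1 to compound 3 (0.09 log units; within the scatter) is within the scatter, so compound 1 and compound 3 are not told apart by this assay.

Compound 4 `CCOC(=O)CSc1nnc(-c2cc(OC)c(OC)c(OC)c2)n1-c1ccc(N(C)C)cc1` has not yet been measured in this assay. It differs from compound 3 by ethoxy in place of cyclopropyl on a carbonyl carbon, which is the same change, at the same place, as that from compound 1 to compound 2. Among the compounds with values here, the only measured instance of this change, an at least 1.6-fold higher number from compound 1 to compound 2 (0.20 log units; that floor lies within the scatter), ran up to the limit, so the expectation for compound 4 is a step of a 1.9-fold higher number from compound 3 to compound 4 (0.27 log units; within the scatter) of that same kind, likely again reaching the limit. On that basis compound 4 is estimated at 85000 nM, within 45000 nM to 200000 nM, with a good chance that only a limit is reported.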

Compound 4, half-maximal inhibitory concentration: > 60000 nM
Compound 4 was reported as a limit; the forecaster's own chance of this, stated with the estimate: 70%; the middle value is on the limit's open side.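

On the core of compound 3, ethoxy in place of cyclopropyl on a carbonyl carbon gives an at least 1.3-fold higher number from compound 3 to compound 4 (0.11 log units; that floor lies within the scatter), and set beside the step on the core of compound 1 the comparison reads: the same change on two cores in this assay, an at least 1.6-fold higher number (0.20 log units; that floor lies within the scatter) from compound 1 to compound 2 and an at least 1.3-fold higher number (0.11 log units; that floor lies within the scatter) from compound 3 to compound 4; the limit leaves it open whether they differ
What this shows is limited: with either core, the compound carrying ethoxy ends at the reporting limit of this assay, a limit and not a number, and the extent of that is: the limit of > 60000 nM in this assay, at which 2 of the 4 values shown sit.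
It does not show that the change has the same size on the two cores or how large it is on either one, and the step between the two compounds carrying ethoxy, compound 2 and compound 4, cannot be read, as both ends are limits.

As far as these compounds go, it remains open whether an amine or a carboxylic acid in place of ethoxy, or a longer chain in place of cyclopropyl, would give a number clearly apart from those of compound 1 and compound 3 in this assay. From the compounds shown here alone, it also remains open whether a halogen or a hydroxyl group, in place of methoxy or dimethylamino on that aromatic carbon, would separate compounds that these two groups do not tell apart.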